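Ethoxy to Phenyl on a Shared Core

The compounds below may be only part of what the source reports. "The series", "measured", "known", "first", "only" and "open" are said of these compounds alone.

Compound 1 `CCOC(=O)/C=C1/C(=O)N2[C@@H]1SC(C)(C)[C@@H]2C(=O)OC(c1ccccc1)c1ccccc1` was tested in a functional assay on OE19 cells (Homo sapiens) for cytotoxicity, read by MTT assay, with a stated time of 48 h (on this read-out higher numbers stand for weaker inhibition and lower numbers for stronger inhibition), and gives 11200 nM. Compound 2 `CC1(C)S[C@@H]2/C(=C\C(=O)OC(c3ccccc3)c3ccccc3)C(=O)N2[C@H]1C(=O)OC(c1ccccc1)c1ccccc1` gives in this assay 21600 nM; the gap between the two numbers lies within the usual scatter of such measurements, so neither compound stands apart from the other. Compound 3 `CC1(C)S[C@@H]2/C(=C\C(=O)c3ccccc3)C(=O)N2[C@H]1C(=O)OC(c1ccccc1)c1ccccc1` is not yet measured. It differs from compound 1 in one place: phenyl in place of ethoxy on a carbonyl carbon. Within the data shown here, no measured pair differing in one place is available, so there is no direct precedent for this change. The step from compound 1 to compound 3 is expected to be a 1.1-fold higher number from compound 1 to compound 3 (0.03 log units; within the scatter), nothing beyond the scatter. In this assay compound 3 is therefore estimated at 12000 nM, with a range from 4000 nM to 40000 nM.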

Compound 3, half-maximal inhibitory concentration: 12800 nM
Compound 3: the middle estimate sits 1.1-fold (0.03 log units) below what was measured; measured number inside the range.
By their numbers in this assay, from the lowest: compounds 1, 3 and 2 (each within the scatter of the next).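

Among these compounds, replacing ethoxy with phenyl on a carbonyl carbon, which turns ethoxycarbonyl into benzoyl, gives the first direct reading at this position: a 1.1-fold higher number from compound 1 to compound 3 (0.06 log units; within the scatter) on the shared core. An aromatic ring of six carbons can therefore take the place of ethoxy, and its oxygen can be lost, without the number leaving the scatter. On these data alone, whether an amine or a longer chain on this carbonyl carbon would move the number beyond the scatter remains open. No measurement at hand gives a reason for this result.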